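The source may report more compounds than this note shows. Statements on the series, on what has been measured and on what is new or still open speak of the compounds shown alone.

In a functional assay on MDA-MB-231 cells (Homo sapiens) for antiproliferative activity, read by MTT assay, with a stated time of 24 h (a lower number here means a stronger inhibitor, a higher number a weaker inhibitor), compound 1 `Cc1ccccc1NNC(=O)c1ccccc1NS(=O)(=O)c1cnc(O)nc1O` gives > 20000 nM, which is a limit of the assay and not a number. Compound 2 `O=C(NNC(=O)c1ccc(NS(=O)(=O)c2cnc(O)nc2O)cc1)c1ccc(F)cc1` gives > 20000 nM, again only a limit. Compound 3 `O=C(NNC(=O)c1ccccc1F)c1cccc(NS(=O)(=O)c2cnc(O)nc2O)c1` gives > 20000 nM, also only a limit. Compound 1 therefore stands with the other two, and no order can be drawn among them: the whole picture so far is the limit of > 20000 nM in this assay, at which 3 of the 3 values shown sit.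

Compound 4 `Cc1ccccc1C(=O)NNC(=O)c1ccccc1NS(=O)(=O)c1cnc(O)nc1O` differs from compound 1 in one place: (2-methylphenyl)carbonyl in place of 2-methylphenyl on an amine nitrogen. Put simply, (2-methylphenyl)carbonyl takes the place of 2-methylphenyl on an amine nitrogen. Going by the values given here, no pair of measured compounds shows what a change of this kind does in this assay. Resting on (the limit of > 20000 nM in this assay, at which 3 of the 3 values shown sit), no step beyond the usual scatter is expected in either direction, and another reading that is only a limit is the likeliest outcome. The estimated step is a number no higher from compound 1 to compound 4 (the limit leaves the size open). Compound 4 is estimated at 20000 nM, with an expected range from 8000 nM to 40000 nM.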

Compound 4, half-maximal inhibitory concentration: 5570 nM
Compound 4: middle estimate off by 3.6-fold (0.56 log units), on the high side; measured number outside the range, below it.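

In this assay, the amine nitrogen of compound 1 proves to be a place where a change can be read: (2-methylphenyl)carbonyl in place of 2-methylphenyl gives an at least 3.5-fold lower number from compound 1 to compound 4 (0.55 log units; beyond the scatter). As far as these compounds go, the true size of this step stays unknown, as compound 1 gives > 20000 nM, which is a limit of the assay and not a number. Compound 4, with 5570 nM, is the only compound shown with a measured number: the limit of > 20000 nM in this assay, at which 3 of the 4 values shown sit.

The compounds shown leave open whether the carbonyl alone accounts for this step or whether the 2-methylphenyl group attached to it also plays a part. A cyclohexyl group, a pyridine ring or a longer alkyl chain on that carbonyl would separate these two readings.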